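Tert-butyl to sec-butyl on the amine of compound 2

The source may report more compounds than this note shows. Statements on the series, on what has been measured and on what is new or still open speak of the compounds shown alone.

Measured compounds:
compound 1, `CCC1CCC(C)N(C[C@@H](O)CNS(=O)(=O)c2cccc3ccccc23)C1`, 1000 nM
compound 2, `CCCN(C[C@@H](O)CNS(=O)(=O)c1cccc2ccccc12)C(C)(C)C`, 1000 nM

Compound 2 was measured in an assay on HEK293 cells for inhibition of sodium- and chloride-dependent glycine transporter 1 (Homo sapiens) (on this read-out lower numbers stand for stronger inhibition and higher numbers for weaker inhibition), and gave 1000 nM, level with compound 1 at the digits shown. Going by the values given here, the only measured step, no change at the digits printed from compound 1 to compound 2 (within the scatter), was within the scatter, although it exchanged the whole amine substituent. Compound 3, `CCCN(C[C@@H](O)CNS(=O)(=O)c1cccc2ccccc12)C(C)CC`, differs from compound 2 in a smaller way: sec-butyl in place of tert-butyl on an amine nitrogen, the two structures having the same atoms joined differently.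

Among the compounds with values here, no measured step changes the branching of an alkyl group on this amine nitrogen, so the expectation rests on how little no change at the digits printed from compound 1 to compound 2 (within the scatter) moved when a ring was replaced by the propyl(tert-butyl)amino group. A rearrangement within the butyl group is a lesser change than that, and a step beyond the scatter is not expected in this assay. For compound 3 the estimate is 1000 nM, with a range from 400 nM to 2500 nM. That estimate means a step of no change at the digits printed from compound 2 to compound 3 (within the scatter), which is within the scatter.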

Compound 3, half-maximal inhibitory concentration: 1260 nM
The estimate for compound 3 lay 1.3-fold (0.10 log units) below the measured number; the measured number falls inside the stated range.
By their numbers in this assay, from the lowest: compounds 1, 2 and 3 (each within the scatter of the next).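

In this assay, going by these compounds alone, sec-butyl in place of tert-butyl on an amine nitrogen whose other neighbours are saturated chain carbons gave the first reading on branching within the butyl group at this place (a 1.3-fold higher number from compound 2 to compound 3 (0.10 log units; within the scatter)), and the two isomeric butyl groups cannot be told apart on this read-out. Replacing the 5-ethyl-2-methylpiperidin-1-yl group of compound 1 with propyl(sec-butyl)amino also stayed within the scatter (a 1.3-fold higher number from compound 1 to compound 3 (0.10 log units; within the scatter)), so the open-chain amine now matches the ring amine with either of two butyl groups rather than with tert-butyl alone. Nothing available explains why these exchanges leave the number within the scatter.

On these data alone, all three compounds lie within the scatter of one another, so it remains open whether any group on this nitrogen can move the number beyond the scatter at all. A methyl group or a cyclopropyl group in place of the butyl group, or a longer chain such as hexyl in place of propyl, would show whether this tolerance extends beyond four-carbon alkyl groups.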